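The source may hold more compounds than are shown below. What is called first, only, known or untested is meant among the compounds shown, and "the series" means these compounds.

Measured so far in a functional assay on MNK45 cells (Homo sapiens) for inhibition, read by MTT assay, with a stated time of 48 h; on this read-out lower numbers stand for stronger inhibition and higher numbers for weaker inhibition:
- compound 1 `Cc1ccc(NC(=S)NC(=O)c2ccc(OCc3ccc(Cl)c(Cl)c3)cc2)cc1-c1nc2ccccc2[nH]1`: 8410 nM
- compound 2 `Cc1ccc(NC(=S)NC(=O)c2ccc(OCc3ccc(Cl)cc3Cl)cc2)cc1-c1nc2ccccc2[nH]1`: 5300 nM

Both compounds share one core and differ only in the pattern of the two chlorine atoms on the benzyl ring attached through the ether oxygen. Going by the values given here, the single measured step, from compound 1 to compound 2, is small: a 1.6-fold lower number from compound 1 to compound 2 (0.20 log units; within the scatter). On the numbers shown, compound 2 and compound 1 therefore sit within the usual scatter of each other, and neither can be called stronger than the other.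

Compound 3 `O=C(NC(=S)Nc1ccc(Cl)c(-c2nc3ccccc3[nH]2)c1)c1ccc(OCc2ccc(Cl)cc2Cl)cc1` keeps everything of compound 2 and alters a different part of the molecule: chloro in place of methyl on an aromatic carbon. Among the compounds with values here, no measured step touches this position; the only step available concerns the chlorinated benzyl ring, far from the site of this change, and it was itself within the scatter. There is thus no basis for expecting a step beyond the scatter in this assay in either direction.

Compound 3 is accordingly estimated at 5000 nM, with a range from 2000 nM to 13000 nM. This estimate corresponds to an expected step of a 1.1-fold lower number from compound 2 to compound 3 (0.03 log units; within the scatter).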

Compound 3, half-maximal inhibitory concentration: 3750 nM
Compound 3: middle estimate off by 1.3-fold (0.12 log units), on the high side, and the stated range covers the measured number.
By their numbers in this assay, from the lowest: compounds 3, 2 and 1 (each within the scatter of the next, the first and the last beyond it).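

In this assay, chloro in place of methyl on the aromatic carbon ortho to a 1H-benzimidazol-2-yl group gives a 1.4-fold lower number from compound 2 to compound 3 (0.15 log units; within the scatter) and so cannot be told apart from repeat-measurement noise. Going by these compounds alone, until now, the only measured change was in the chlorine pattern on the benzyl ring; this is the first look at the other end of the molecule, and here, too, swapping one heavy atom for another, neither group carrying hydrogen-bond donors, hydrogen-bond acceptors or net charge, produces no step beyond the scatter. No measurement is available that could explain the result or tie it to any property of the two groups.

The compounds shown say nothing about how this position responds to a group of another kind, such as an amine, a carboxylic acid or a longer alkyl chain, or to a bare hydrogen with no substituent at all. Going by these compounds, it also remains open whether chloro in place of methyl would give a similar result when paired with the 3,4-dichlorophenyl arrangement of compound 1.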